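This account rests on a few compounds, and the source may have more. Where it says the series, first, only, none or still open, it means among the compounds named here.

Measured compounds:
compound 1, `COc1ccc(-c2cn(-c3ccc(O)c(C(=O)Nc4cccc(C(F)(F)F)c4)c3)nn2)cc1`: 9%
compound 2, `COc1ccc(OC)c(-c2cn(-c3ccc(O)c(C(=O)OCCCc4ccccc4)c3)nn2)c1`: 13%
compound 3, `COC(=O)c1cc(-n2cc(-c3cccc(O)c3)nn2)ccc1O`: 6%

All three were run in a functional assay on HCT-116 cells (Homo sapiens) for inhibition, read by MTT assay, with a stated time of 2 days, tested at 10 uM; on this read-out lower numbers stand for less inhibition and higher numbers for more inhibition at the one concentration tested (going by the name of the read-out). In this assay compound 1 gives 9%. Compound 3 gives 6% and compound 2 gives 13%. The number for compound 1 lies within the scatter of both other numbers, so the three compounds cannot be ordered against one another; each shows only modest inhibition at the single concentration tested. Going by the values given here, no pair of measured compounds differs in just one place, so the set holds no measured step that would show how a single change moves the read-out.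

Compound 4, `COc1cc(OC)cc(-c2cn(-c3ccc(O)c(C(=O)Nc4cccc(C(F)(F)F)c4)c3)nn2)c1`, has not yet been measured in this assay. Against compound 1 the change is one alteration: 3,5-dimethoxyphenyl in place of 4-methoxyphenyl on an aromatic carbon. With compounds 1, 2 and 3 all low despite their differing substituents, the expectation for this step is no movement beyond the scatter, and the estimated step of a number 1 percentage points higher from compound 1 to compound 4 (within the scatter) reflects that. For compound 4 the expected value in this assay is 10%, with a range from 0% to 22%.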

Compound 4, a percentage reported as inhibition, at one concentration (the size of the read-out at that concentration, not a potency): 62%
The estimate for compound 4 lay 52 percentage points below the measured number; measured number outside the range, above it.
By their numbers in this assay, from the lowest: compounds 3, 1 and 2 (each within the scatter of the next); then compound 4.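

In this assay, going by these compounds alone, the aryl group on an aromatic carbon of the five-membered aromatic ring with 3 nitrogen proves to be a place where one change can move the read-out: 3,5-dimethoxyphenyl in place of 4-methoxyphenyl gives a number 53 percentage points higher from compound 1 to compound 4 (beyond the scatter), the first measured step and one beyond the scatter. The earlier compounds shown here could not show this, as they held no single-place step and their numbers lay within the scatter of one another. Nothing at hand bears on the reason for this rise, which comes with 3,5-dimethoxyphenyl having 10 heavy atoms and 2 hydrogen-bond acceptors against 8 and 1 for 4-methoxyphenyl.

This one step changes both the number and the placement of the methoxy groups, so it leaves open which of the two carries the rise, and whether groups such as 3,5-dichlorophenyl or 3,5-diaminophenyl would do the same. Also open, as far as these compounds go, is whether the step would hold on a core with a carboxylic acid in place of the amide bearing the trifluoromethyl-substituted phenyl.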